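This account rests on a few compounds, and the source may have more. Where it says the series, first, only, none or still open, it means among the compounds named here.

For the measured compounds named here, compound 1 `Fc1cccc(F)c1Cc1cnc(Nc2ccc(-c3ccncc3)c(Cl)c2)o1` is one of three compounds tested in an ADME assay on MT2 cells (Homo sapiens) for cytotoxicity, read by MTT assay (on this read-out higher numbers stand for lower toxicity in this test and lower numbers for higher toxicity in this test), and in this assay compound 1 gives 9300 nM, the only number among the three values shown. Compound 2 `Clc1cccc(Cl)c1Cc1nnc(Nc2ccc(COCc3ccccn3)cc2)o1` reaches only a limit of this assay, > 100000 nM. Compound 3 `Clc1cccc(Cl)c1Cc1nnc(Nc2ccc(COCc3ccsc3)cc2)o1` likewise reaches only a limit, > 100000 nM. Going by the values given here, the one measured step, a step that the two limits leave unreadable from compound 2 to compound 3, is therefore unreadable, and the limit of > 100000 nM in this assay, at which 2 of the 3 values shown sit, marks where those two values sit. Compound 4 `Fc1cccc(F)c1Cc1cnc(Nc2ccc(COc3ccncc3)c(Cl)c2)o1` differs from compound 1 by ((pyridin-4-yl)oxy)methyl in place of pyridin-4-yl on an aromatic carbon. Among the compounds with values here, no measured step covers this change, so no direction beyond the scatter can be taken from the data. Compound 4 is expected to show a step of a 2.7-fold higher number from compound 1 to compound 4 (0.43 log units; beyond the scatter). The estimate for compound 4 in this assay is 25000 nM, between 5000 nM and 100000 nM.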

Compound 4, half-maximal cytotoxic concentration: 3800 nM
Beside the measured number, compound 4's estimate is 6.6-fold (0.82 log units) above it, outside the stated range (below it).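

For the compounds shown here, at this aromatic carbon, ((pyridin-4-yl)oxy)methyl in place of pyridin-4-yl gives the first readable step in this assay, a 2.4-fold lower number from compound 1 to compound 4 (0.39 log units; beyond the scatter), since the earlier step between limits cannot be read. The step is modest but beyond the scatter, and it runs towards higher toxicity in this test, so the read-out responds to a change at this position. Compound 2 and compound 3 each still give only a limit, not a number: the limit of > 100000 nM in this assay, at which 2 of the 4 values shown sit. The compounds shown leave open how an amine, a carboxylic acid or a longer chain at this aromatic carbon would read in this test.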